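This account rests on a few compounds, and the source may have more. Where it says the series, first, only, none or still open, it means among the compounds named here.

Measured so far in an ADME assay on a cell-free system (plasma, Homo sapiens) for protein binding, read by LC-MS, with a stated time of 5 h, tested at 10 uM:
compound 1 `OC[C@H]1O[C@H](Oc2ccc(-n3ccc4ccccc43)cc2Cl)[C@@H](O)[C@@H](O)[C@@H]1O`: 98%
compound 2 `O=[N+]([O-])c1ccc2c(ccn2-c2ccc(O[C@H]3O[C@H](CO)[C@@H](O)[C@H](O)[C@@H]3O)c(Cl)c2)c1`: 99%

Compound 2, at 99%, lies within the scatter of compound 1, at 98%, so neither stands apart from the other. Next in the series is compound 3 `COc1ccc2c(ccn2-c2ccc(O[C@H]3O[C@H](CO)[C@@H](O)[C@H](O)[C@@H]3O)c(Cl)c2)c1`. It differs from compound 2 by methoxy in place of nitro on an aromatic carbon. Within the data shown here, one measured step bears on this place, nitro in place of hydrogen, and no measured compound carries methoxy. Among the measured compounds shown here, with a 2.0-fold lower unbound fraction from compound 1 to compound 2 (0.30 log units; within the scatter) as the only measured change there, no step beyond the scatter is expected in this assay. The expected change is a 2.0-fold higher unbound fraction from compound 2 to compound 3 (0.30 log units; within the scatter). For compound 3 the estimated value is 98%, with an expected range of 96% to 99.5%.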

Compound 3, plasma protein binding: 96%
Beside the measured number, compound 3's estimate is 2.0-fold (0.30 log units) (unbound fraction) below it; low and high end bracket the measured number.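

In this assay, this position now shows a step beyond the scatter: methoxy in place of nitro gives a 4.0-fold higher unbound fraction from compound 2 to compound 3 (0.60 log units; beyond the scatter). Methoxy in place of hydrogen stays within the scatter, at a 2.0-fold higher unbound fraction from compound 1 to compound 3 (0.30 log units; within the scatter), as does nitro in place of hydrogen, at a 2.0-fold lower unbound fraction from compound 1 to compound 2 (0.30 log units; within the scatter), so the position responds to the choice of group, but only the nitro and methoxy pair shows it. Nothing at hand speaks to the cause of this step.

As far as these compounds go, whether an amine, a carboxylic acid or a longer chain on this aromatic carbon would separate from hydrogen in this assay stays open. From the compounds shown here alone, with only hydrogen, nitro and methoxy compared here, it also stays open whether the step from nitro to methoxy would hold with a change elsewhere on the shared core.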